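Nitro for ethoxy: expected half-life of compound 3

The source may report more compounds than this note shows. Statements on the series, on what has been measured and on what is new or still open speak of the compounds shown alone.

Measured so far in an ADME assay for pharmacokinetics; a lower number here means that the compound disappears faster, a higher number that the compound lasts longer:
- compound 1 (`CCOc1ccc(-n2nnc3c(C(N)=O)ncn3c2=O)cc1`) gives 1.3 h
- compound 2 (`CCCn1nnc2c(C(N)=O)ncn2c1=O`) gives 2.58 h

Compound 1 (1.3 h) and compound 2 (2.58 h) lie within the scatter of each other, so compound 1 holds no distinct place on these two numbers. The next compound to be measured is compound 3 (`NC(=O)c1ncn2c(=O)n(-c3ccc([N+](=O)[O-])cc3)nnc12`), which carries nitro in place of ethoxy on an aromatic carbon, para to a large group (nitro in place of ethoxy on an aromatic carbon). Within the data shown here, no measured pair isolates a change at this place, so the data give no direct size for it. The expected result is a 1.3-fold lower number from compound 1 to compound 3 (0.11 log units; within the scatter) in this assay, a small downward move that stays within the scatter. Compound 3 is estimated at 1 h (expected range 0.5 h to 2 h).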

Compound 3, half-life: < 0.0167 h
Compound 3: no number, only a limit; the forecaster's own chance of this, stated with the estimate: 3%; at least 59-fold (1.77 log units) between middle value and limit.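

In this assay, nitro in place of ethoxy on an aromatic carbon, para to a large group, gives an at least 77-fold lower number from compound 1 to compound 3 (1.89 log units; beyond the scatter), the first size seen for a change at this place. The step lies beyond the scatter, although ethoxy and nitro each hold 3 heavy atoms, so this place is not indifferent to the group it carries. From the compounds shown here alone, compound 3 gives < 0.0167 h, which is a limit of the assay and not a number, so the full size of the step stays unknown: the limit of < 0.0167 h in this assay, at which 1 of the 3 values shown sits.

With only ethoxy and nitro shown at this place, it remains open whether the drop belongs to nitro itself or to the loss of ethoxy. An amine or a chlorine at the same aromatic carbon would help separate these two readings.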